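Nitro in place of trifluoromethyl: an expected small step

This account rests on a few compounds, and the source may have more. Where it says the series, first, only, none or still open, it means among the compounds named here.

Compound 1 `O=C(N/N=C/c1cc(I)c(O)c(I)c1)c1ccc(O)cc1` and compound 2 `O=C(N/N=C/c1cc(I)c(O)c(I)c1)c1ccc(C(F)(F)F)cc1` share a core and differ at one aromatic carbon. In a functional assay on HepG2 cells (Homo sapiens) for cytotoxicity, with a stated time of 24 h (a lower number here means a stronger inhibitor, a higher number a weaker inhibitor), compound 1 gives 110000 nM, and compound 2 gives 57400 nM, the lower of the two numbers, although a 1.9-fold lower number from compound 1 to compound 2 (0.28 log units; within the scatter). Compound 3 `O=C(N/N=C/c1cc(I)c(O)c(I)c1)c1ccc([N+](=O)[O-])cc1` carries nitro in place of trifluoromethyl on an aromatic carbon. Among the measured compounds shown here, the only step that bears on this position, a 1.9-fold lower number from compound 1 to compound 2 (0.28 log units; within the scatter), stayed within the scatter, so no change beyond the scatter is expected in this assay for compound 3, with a 1.0-fold lower number from compound 2 to compound 3 (0.02 log units; within the scatter). Compound 3 is therefore estimated at 55000 nM, between 20000 nM and 150000 nM.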

Compound 3, half-maximal inhibitory concentration: 92100 nM
The estimate for compound 3 lay 1.7-fold (0.22 log units) below the measured number; the range from low to high includes it.
By their numbers in this assay, from the lowest: compounds 2, 3 and 1 (each within the scatter of the next).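

In this assay nitro, on an aromatic carbon para to a large group, gives a number that cannot be told apart from those of trifluoromethyl (a 1.6-fold higher number from compound 2 to compound 3 (0.21 log units; within the scatter)) and hydroxy (a 1.2-fold lower number from compound 1 to compound 3 (0.08 log units; within the scatter)). Across these three compounds, then, changing this group leaves the number within the scatter, so the first flat step was not a one-off between two groups. No measurement at hand explains this flat result. On these data alone, whether an amine, a carboxylic acid or a longer chain at this place would move the number beyond the scatter remains open.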